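Oxime ether in place of isoxazole on an imidazoline scaffold

The source may hold more compounds than are shown below. What is called first, only, known or untested is meant among the compounds shown, and "the series" means these compounds.

The series shares an imidazoline-bearing aniline core, varied in one substituent on the benzene ring. In a functional assay for activation of Alpha-1D adrenergic receptor (Homo sapiens) (a lower number here means that less compound is needed, a higher number that more compound is needed for the effect), compound 1 `c1ccc(-c2cnoc2)c(NCC2=NCCN2)c1` gives only a limit, < 100000 nM. Compound 2 `Cc1cccnc1-c1ccccc1NCC1=NCCN1` likewise gives only a limit in this assay, < 100000 nM. Compound 3 `Nc1nccc(-c2ccccc2NCC2=NCCN2)n1` gives 28.8 nM in this assay. Within the data shown here, compound 1 therefore stands on a limit rather than a number, and the evidence in this assay is the limit of < 100000 nM in this assay, at which 2 of the 3 values shown sit, so no measured step can be stated.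

Compound 4 `CO/N=C(\C)c1ccccc1NCC1=NCCN1` differs from compound 1 by a group of 5 heavy atoms (3 carbon, 1 nitrogen, 1 oxygen; no ring) in place of a group of 5 heavy atoms (3 carbon, 1 nitrogen, 1 oxygen; one five-membered aromatic ring with 2 hetero atoms), on an aromatic carbon. Since compound 1 has only a limit, the step that the limit leaves unreadable from compound 1 to compound 4 is expected to be of unknown direction and size. Compound 4 is estimated at 2000 nM in this assay, within 100 nM to 40000 nM, with a real chance that only a limit is reported.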

Compound 4, half-maximal effective concentration: < 5020 nM
Compound 4 was reported as a limit (the forecaster's own chance of this, stated with the estimate: 40%); the middle value lies beyond the limit too.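

Compound 1 and compound 4 are both reported only as limits in this assay, so the step between them cannot be read. As far as these compounds go, it remains open whether replacing the 1,2-oxazol-4-yl group of compound 1 with the ring-free group of compound 4 changes the concentration needed for activation, and in which direction.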